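The source may report more compounds than this note shows. Statements on the series, on what has been measured and on what is new or still open speak of the compounds shown alone.

Working notes on the series in a functional assay on SK-MEL-2 cells (Homo sapiens) for inhibition, read by sulforhodamine B assay, with a stated time of 48 h, tested at 10 uM; a higher number here means more inhibition at the concentration tested (going by the name of the read-out), a lower number less inhibition. Compound 1 `COc1ccc(-c2cn3ccnc3c(-c3ccc4ncn(C5CCCCC5)c4c3)n2)cc1` gives 94.3%, compound 2 `CC(=O)c1ccc(-c2cn3ccnc3c(-c3ccc4ncn(C5CCCCC5)c4c3)n2)cc1` gives 0.58%, and compound 3 `CCc1ccc(-c2cn3ccnc3c(-c3ccc4ncn(Cc5ccccc5)c4c3)n2)cc1` gives 14.8%. Compound 3 therefore stands second highest of the three numbers, beyond the scatter from both neighbours. Going by the values given here, the only step known, a number 93.7 percentage points lower from compound 1 to compound 2 (beyond the scatter), concerns acetyl in place of methoxy and does not touch the ring swap that leads to compound 4 `c1ccc(Cn2cnc3ccc(-c4nc(-c5cccc6ccccc56)cn5ccnc45)cc32)cc1`: naphthalen-1-yl in place of 4-ethylphenyl on an aromatic carbon. Among the compounds with values here, no measured pair shows what this kind of change does, so no direction is supported beyond the scatter. For compound 4 the expected value is set near that of compound 3, at 20% with a range of 0% to 55%. The expected step is thus a number 5.2 percentage points higher from compound 3 to compound 4 (within the scatter).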

Compound 4, a percentage reported as inhibition, at one concentration (the size of the read-out at that concentration, not a potency): 17%
For compound 4 the middle estimate is 3 percentage points above the measured one; measured number inside the range.
By their numbers in this assay, from the lowest: compound 2; then compounds 3 and 4 (each within the scatter of the next); then compound 1.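

In this assay, naphthalen-1-yl in place of 4-ethylphenyl on this aromatic carbon of the shared core gives a number 2.2 percentage points higher from compound 3 to compound 4 (within the scatter). At this position, then, exchanging one aromatic ring for two leaves the read-out unchanged for this pair, the first measured case of a change here that stays within the scatter. Nothing available explains this result. Open, from the compounds shown here alone, is whether an amine or a carboxylic acid on the same carbon would shift the read-out. Also open, going by these compounds, is whether naphthalen-1-yl behaves alike with cyclohexyl in place of the benzyl group.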